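The compounds below may be only part of what the source reports. "The series", "measured", "known", "first", "only" and "open" are said of these compounds alone.

Compound 1 `O=C1[C@@H](NS(=O)(=O)c2cc3nc(Cl)ccc3s2)CCN1Cc1cc2[nH]cccc-2n1` gives 48% in an assay on isolated protein for inhibition of coagulation factor X (Oryctolagus cuniculus), tested at 0.5 uM; on this read-out lower numbers stand for less inhibition and higher numbers for more inhibition at the one concentration tested (going by the name of the read-out). Compound 2 `O=C1[C@@H](NS(=O)(=O)c2cc3ccnc(Cl)c3s2)CCN1Cc1cc2cc[nH]cc-2n1` gives 48% in this assay and compound 3 `O=C1[C@@H](NS(=O)(=O)c2cc3c(Cl)nccc3s2)CCN1Cc1cc2[nH]cccc-2n1` gives 50%. Compound 1 thus stands level with compound 2 at the digits shown, the two together the lowest of the three numbers, and the only single-place step recorded, a number 2 percentage points higher from compound 1 to compound 3 (within the scatter), lies within the scatter. Compound 4 `O=C1[C@@H](NS(=O)(=O)c2cc3ccc(Cl)cc3s2)CCN1Cc1cc2[nH]cccc-2n1` differs from compound 1 by a group of 10 heavy atoms (8 carbon, 1 sulfur, 1 chlorine; one five-membered aromatic ring with 1 hetero atom, one six-membered aromatic ring of carbon only) in place of a group of 10 heavy atoms (7 carbon, 1 nitrogen, 1 sulfur, 1 chlorine; one five-membered aromatic ring with 1 hetero atom, one six-membered aromatic ring with 1 hetero atom), on a sulfonyl sulfur. For the measured compounds named here, the one step that bears on this, an exchange of the bicyclic group on the same sulfonyl sulfur, moved nothing beyond the scatter, so no step beyond the scatter is expected here either, in either direction. Compound 4 is therefore estimated at 46%, with a range of 30% to 62%, meaning an expected step of a number 2 percentage points lower from compound 1 to compound 4 (within the scatter).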

Compound 4, a percentage reported as inhibition, at one concentration (the size of the read-out at that concentration, not a potency): 64%
Estimate against measurement, compound 4: 18 percentage points below; the measured number lies above the stated range.
By their numbers in this assay, from the lowest: compounds 1, 2 and 3 (each within the scatter of the next); then compound 4.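

For the compounds shown here, on the sulfonyl sulfur, the exchange for 6-chloro-1-benzothiophen-2-yl gives the first steps beyond the scatter in this assay: a number 16 percentage points higher from compound 1 to compound 4 (beyond the scatter) and a number 14 percentage points higher from compound 3 to compound 4 (beyond the scatter) are both modest. This position therefore responds to the group placed on it, and both steps go with a six-membered aromatic ring of carbon only in place of one with a hetero atom. Nothing available explains these steps.

The compounds shown leave open what the chlorine contributes, and whether a methyl or methoxy group in its place would hold the higher number. They also leave open whether an amine on that ring would give a higher, lower or level number.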